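A few compounds are considered here, and "the series" means these few. Any claim that something is new, unique, unknown or untested is made for them only; others in the source may bear on it.

Measured compounds:
Compound 1 `O=C(c1ccnc2cc(Br)ccc12)N1CCCCC1`: > 20000 nM
Compound 2 `COc1ccc(-c2ccc3c(C(=O)Nc4cccc(F)c4)cc(=O)[nH]c3c2)cc1`: > 20000 nM

In a functional assay on KYSE-70 cells for antiproliferative activity against KYSE-70 cell line (Homo sapiens), read by MTT assay, with a stated time of 72 h (on this read-out higher numbers stand for weaker inhibition and lower numbers for stronger inhibition), compound 1 gives > 20000 nM; this is a limit of the assay and not a number. In this assay compound 2 gives > 20000 nM, likewise a limit of the assay rather than a number. Compound 2 therefore stands where every value shown stands, namely at the limit of > 20000 nM in this assay, at which 2 of the 2 values shown sit.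

Compound 3, `Cc1cc(-c2ccc3c(C(=O)Nc4cccc(F)c4)cc(=O)[nH]c3c2)c(C)cc1F`, differs from compound 2 in one place: 4-fluoro-2,5-dimethylphenyl in place of 4-methoxyphenyl on an aromatic carbon.

For the measured compounds named here, no pair of measured compounds differing in a single place is available, so the size of such a step cannot be read from measured neighbours. Given that compound 2 sits at a limit, the expected step from compound 2 to compound 3 is a number no higher from compound 2 to compound 3 (the limit leaves the size open), that is, none beyond the scatter in this assay. Compound 3 is expected to give 20000 nM in this assay, with a range from 5000 nM to 40000 nM.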

Compound 3, half-maximal inhibitory concentration: > 20000 nM
Compound 3: a limit, no number (the forecaster's own chance of this, stated with the estimate: 65%); the middle value sits exactly at the limit.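

For the compounds shown here, compound 2 and compound 3 both give limits of the assay and not numbers, so no step between them can be read in this assay. The compounds shown leave open which structure, if any, would give a measurable value: the limit of > 20000 nM in this assay, at which 3 of the 3 values shown sit.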